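The source may report more compounds than this note shows. Statements on the series, on what has been measured and on what is new or still open speak of the compounds shown alone.

Measured compounds in the series so far:

Compound 1 `O=C1C(Nc2ccccc2F)=CC(=O)c2c1nc1n2[C@H]2OC[C@@H](O)[C@H]2OC1` gives 2660 nM in a functional assay on ECa-109 cells for inhibition, with ECa-109 cell line (Homo sapiens) as the target, read by sulforhodamine B assay; on this read-out lower numbers stand for stronger inhibition and higher numbers for weaker inhibition.
Compound 2 `O=C1C(Nc2ccc(Br)cc2)=CC(=O)c2c1nc1n2[C@H]2OC[C@@H](O)[C@H]2OC1` gives 1980 nM in this assay.
Compound 3 `O=C1C(Nc2ccc(C(F)(F)F)cc2)=CC(=O)c2c1nc1n2[C@H]2OC[C@@H](O)[C@H]2OC1` gives 2250 nM in this assay.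

Compound 3 stands second highest of the three numbers. Its nearest neighbour is compound 2: a 1.1-fold higher number from compound 2 to compound 3 (0.06 log units; within the scatter). The other comparison is a 1.2-fold lower number from compound 1 to compound 3 (0.07 log units; within the scatter). All three measured values thus sit within the scatter of one another, and no ordering among them can be read from the data.

Compound 4 `O=C1C(Nc2cccc(Cl)c2)=CC(=O)c2c1nc1n2[C@H]2OC[C@@H](O)[C@H]2OC1` is the next compound. It differs from compound 3 in one place: 3-chlorophenyl in place of 4-(trifluoromethyl)phenyl on an amine nitrogen.

Every measured step in the set bears on this kind of change, since each exchanges the aryl group on the amine nitrogen: a 1.3-fold lower number from compound 1 to compound 2 (0.13 log units; within the scatter), a 1.2-fold lower number from compound 1 to compound 3 (0.07 log units; within the scatter) and a 1.1-fold higher number from compound 2 to compound 3 (0.06 log units; within the scatter). None of them left the scatter. A 3-chlorophenyl has not been measured anywhere in the series, so no direct precedent exists, but the three steps together give no reason to expect this exchange to behave differently. The expected step is therefore a 1.0-fold higher number from compound 3 to compound 4 (0.01 log units; within the scatter), which is none beyond the scatter.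

Compound 4 is accordingly estimated at 2300 nM in this assay, with an expected range from 1200 nM to 4600 nM.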

Compound 4, half-maximal inhibitory concentration: 3080 nM
Beside the measured number, compound 4's estimate is 1.3-fold (0.13 log units) below it; the range from low to high includes it.
By their numbers in this assay, from the lowest: compounds 2, 3, 1 and 4 (each within the scatter of the next).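

In this assay, 3-chlorophenyl on the amine nitrogen stays within the scatter of all three earlier aryl groups (a 1.4-fold higher number from compound 3 to compound 4 (0.14 log units; within the scatter); a 1.6-fold higher number from compound 2 to compound 4 (0.19 log units; within the scatter); a 1.2-fold higher number from compound 1 to compound 4 (0.06 log units; within the scatter)). The series now spans four aryl groups, 2-fluorophenyl, 4-bromophenyl, 4-(trifluoromethyl)phenyl and 3-chlorophenyl, with no separation among them at this position, and the exchange of a group of 10 heavy atoms for one of 7 also stays inside the scatter. The compounds shown carry no information that would explain this lack of separation.

Going by these compounds, all four aryl groups carry fluorine, chlorine or bromine, so it remains open whether a phenyl bearing a carboxylic acid, an amine or a methoxy group, or a longer alkyl chain in place of the aryl group, would move the number beyond the scatter. On these data alone, the hydroxyl group on the shared core also stays the same throughout, so whether changes away from the amine nitrogen have any larger effect remains open as well.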